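A few compounds are considered here, and "the series" means these few. Any claim that something is new, unique, unknown or untested is made for them only; others in the source may bear on it.

Measured so far in a functional assay on MDA-MB-231 cells (Homo sapiens) for inhibition, read by sulforhodamine B assay, with a stated time of 72 h; on this read-out lower numbers stand for stronger inhibition of growth and higher numbers for weaker inhibition of growth:
- compound 1 `NNC(=O)CCc1ccncc1-c1ccc2ccccc2c1` gives > 10000 nM (a limit of the assay)
- compound 2 `CNC(=O)/C=C/c1ccncc1-c1ccc2cc[nH]c2c1` gives 7680 nM (a number)
- compound 3 `O=C(O)/C=C/c1ccncc1-c1ccc2ccccc2c1` gives > 10000 nM (a limit of the assay)

Compound 3 has no number, only > 10000 nM as a limit of the assay. The series is dominated by the limit of > 10000 nM in this assay, at which 2 of the 3 values shown sit, and compound 3 shares that position with compound 1. Within the data shown here, the one measured step touching compound 3 is a step that the two limits leave unreadable from compound 1 to compound 3 and it offers no size to carry over.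

Compound 4 `CN(C)C(=O)/C=C/c1ccncc1-c1ccc2ccccc2c1` follows from compound 3 by dimethylamino in place of hydroxy on a carbonyl carbon and reads dimethylamino in place of hydroxy on a carbonyl carbon. Among the measured compounds shown here, no measured step covers this change. Compound 2 also carries an amide and gives 7680 nM on a different core, which is only a loose hint for compound 4. Little movement is expected in this assay, if any then towards stronger inhibition, and another limit reading is quite possible. The expected step is an at least 1.1-fold lower number from compound 3 to compound 4 (0.04 log units; that floor lies within the scatter) as far as it can be read at all. For compound 4 the estimated value is 9000 nM with an expected range from 3000 nM to 20000 nM as the working figure.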

Compound 4, concentration for 50% growth inhibition: 7990 nM
The estimate for compound 4 lay 1.1-fold (0.05 log units) above the measured number; measured number inside the range.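

In this assay, among these compounds, compound 4 gives 7990 nM as the only number on the core of compound 1, so dimethylamino in place of hydroxy on a carbonyl carbon can be sized from one side, as an at least 1.2-fold lower number from compound 3 to compound 4 (0.09 log units; that floor lies within the scatter) and, for the whole chain, as an at least 1.2-fold lower number from compound 1 to compound 4 (0.09 log units; that floor lies within the scatter). Both floors lie within the scatter, so neither establishes a real gain, and the remaining step on this core cannot be read. Both sizes stay floors because one end of each step is a limit, not a number: the limit of > 10000 nM in this assay, at which 2 of the 4 values shown sit.

Open, on these data alone, is whether the reading depends on the dimethylamino group itself or on any amide at this carbonyl carbon, which a morpholine amide or a methyl ester would test. Also open, as far as these compounds go, is the part played by the double bond, which a saturated 2-(dimethylcarbamoyl)ethyl chain would address.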